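Cyclobutyl to cyclopentyl on the chain of compound 2

This account rests on a few compounds, and the source may have more. Where it says the series, first, only, none or still open, it means among the compounds named here.

Compound 1 `COCCn1nc(-c2cccs2)c(O)c(C2=NS(=O)(=O)c3cc(NS(C)(=O)=O)ccc3N2)c1=O`: > 1000 nM
Compound 2 `CS(=O)(=O)Nc1ccc2c(c1)S(=O)(=O)N=C(c1c(O)c(-c3cccs3)nn(CCC3CCC3)c1=O)N2`: > 1000 nM

In an ADME assay on Huh-7 cells (Homo sapiens) for cytotoxicity, with a stated time of 72 h (on this read-out lower numbers stand for higher toxicity in this test and higher numbers for lower toxicity in this test), compound 1 gives > 1000 nM, which is a limit and not a number. Compound 2 gives > 1000 nM, which is also a limit. Compound 2 therefore has no exact position on the scale, and the data so far amount to the limit of > 1000 nM in this assay, at which 2 of the 2 values shown sit.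

Compound 3 `CS(=O)(=O)Nc1ccc2c(c1)S(=O)(=O)N=C(c1c(O)c(-c3cccs3)nn(CCC3CCCC3)c1=O)N2` differs from compound 2 in one place: cyclopentyl in place of cyclobutyl on a saturated chain carbon, two bonds along the chain from an aromatic nitrogen. Cyclopentyl stands in place of cyclobutyl on a saturated chain carbon, two bonds along the chain from an aromatic nitrogen.

Among the compounds with values here, one measured step bears on this change, since it falls at the same place: a step that the two limits leave unreadable from compound 1 to compound 2. Its size cannot be read, so it offers no measured size to carry over. No step beyond the usual scatter is expected in this assay, in either direction. The expectation rests on the limit of compound 2 at > 1000 nM. The expected change is a step that the limit leaves unreadable from compound 2 to compound 3. Compound 3 is estimated at 3000 nM, with an expected range from 1000 nM to 10000 nM.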

Compound 3, half-maximal cytotoxic concentration: > 1000 nM
Compound 3: no number, only a limit; the forecaster's own chance of this, stated with the estimate: 85%; the middle value is on the limit's open side.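

In this assay compound 3 gives > 1000 nM, which is a limit and not a number. The steps joining compound 1, compound 2 and compound 3 therefore cannot be read. The data so far amount to this: the limit of > 1000 nM in this assay, at which 3 of the 3 values shown sit.

The compounds shown leave open where each lies on the scale, and whether the chain groups differ in this test at all.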